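Replacing the ethoxyphenyl of compound 1 with a cyclooctyl ring

This account rests on a few compounds, and the source may have more. Where it says the series, first, only, none or still open, it means among the compounds named here.

Compound 1 `CCOc1ccc(C2(c3ccc(O)cc3)C(=O)Nc3c2ccc(F)c3F)cc1` gives 24 nM in a functional assay on PC-3 cells (Homo sapiens) for cytotoxicity, read by WST assay, with a stated time of 72 h (a lower number here means a stronger inhibitor, a higher number a weaker inhibitor), the lowest of the two numbers shown; compound 3 `COc1ccc(C2(c3cccc(O)c3)C(=O)Nc3c2ccc(F)c3F)cc1` gives 145 nM, a higher number. Compound 2 `CCCCCOc1ccc(C2(c3ccc(O)cc3)C(=O)Nc3c2ccc(F)c3F)cc1` reaches only a limit, > 1000 nM, (the limit of > 1000 nM in this assay, at which 1 of the 3 values shown sits). Among the compounds with values here, the one measured step, an at least 41-fold higher number from compound 1 to compound 2 (1.61 log units; beyond the scatter), shows that extending the chain on that aryl ether costs much. Compound 4 `O=C1Nc2c(ccc(F)c2F)C1(c1ccc(O)cc1)C1CCCCCCC1` differs from compound 1 more deeply: cyclooctyl in place of 4-ethoxyphenyl on a saturated ring carbon. Within the data shown here, no measured step exchanges this aromatic ring for a saturated one, so the step from compound 1 to compound 2 is only a loose guide. For compound 4 a sizeable loss is expected, estimated as a 21-fold higher number from compound 1 to compound 4 (1.32 log units; beyond the scatter). Compound 4 is therefore expected to give about 500 nM, plausibly between 80 nM and 3000 nM.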

Compound 4, half-maximal inhibitory concentration: > 1000 nM
Compound 4 gave a limit, no number (the forecaster's own chance of this, stated with the estimate: 35%); at least 2.0-fold (0.30 log units) between middle value and limit.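

The earlier compounds shown here all kept an aromatic ring on the saturated ring carbon. Here cyclooctyl replaces 4-ethoxyphenyl at that carbon, and this assay shows an at least 41-fold higher number from compound 1 to compound 4 (1.61 log units; beyond the scatter), so in this pair the exchange of the aromatic ring for a saturated one carries a large cost. Compound 4 stands at a limit of the assay, not at a number: the limit of > 1000 nM in this assay, at which 2 of the 4 values shown sit.

Going by these compounds, whether a smaller saturated ring such as cyclohexyl, or an unsubstituted phenyl, would fare better at this carbon stays open. The compounds shown also do not separate the loss of the aromatic ring from the loss of the ethoxy group.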